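A few compounds are considered here, and "the series" means these few. Any claim that something is new, unique, unknown or untested is made for them only; others in the source may bear on it.

Working notes on the series. Compound 1 `CC1(C)CCC(C)(C)c2cc(-c3cccc(-c4ccc(C(=O)O)cc4)c3)ccc21` carries a hydrogen where compound 2 `Cc1ccc(-c2ccc(C(=O)O)cc2)cc1-c1ccc2c(c1)C(C)(C)CCC2(C)C` carries a methyl group on an aromatic carbon; in an assay on CV-1 cells (Cercopithecidae) for activation of retinoic acid receptor beta (Homo sapiens) (on this read-out lower numbers stand for an effect already at smaller amounts and higher numbers for an effect only at larger amounts of compound), compound 1 gives 4.3 nM. In this assay compound 2 is reported only as a limit, < 1 nM, so its position on the numbers is known as a bound and not as a figure, the bound being (the limit of < 1 nM in this assay, at which 1 of the 2 values shown sits). For the measured compounds named here, the only measured step, an at least 4.3-fold lower number from compound 1 to compound 2 (0.63 log units; beyond the scatter), is therefore open at its lower end.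

Compound 3 `Cc1ccc(-c2ccc(C(=O)O)cc2)cc1-c1cc2c(cc1C)C(C)(C)CCC2(C)C` takes the same kind of change one place further: methyl in place of hydrogen on an aromatic carbon. Going by the values given here, the single measured step of this type came with a methyl on a different ring, so it bears on the new one only by analogy; a second methyl need not repeat the gain. The expectation is a number for compound 3 near the bound of compound 2 or somewhat higher, with the step of an at least 2.0-fold higher number from compound 2 to compound 3 (0.30 log units; that floor lies within the scatter) estimated as small to modest. For compound 3 the estimate in this assay is 2 nM, within a range of 0.5 nM to 10 nM, with a real chance that only a limit is returned again.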

Compound 3, concentration for half-maximal activity: 10 nM
Compound 3: the middle estimate sits 5.0-fold (0.70 log units) below what was measured; measured number inside the range.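

The same change does not act the same way at every place in the series. In this assay, a methyl in place of hydrogen on an aromatic carbon of the six-membered ring in the fused system, ortho to a large group, gives an at least 10-fold higher number from compound 2 to compound 3 (1.00 log units; beyond the scatter), whereas the methyl on the other ring gave an at least 4.3-fold lower number from compound 1 to compound 2 (0.63 log units; beyond the scatter); both steps lie beyond the scatter and run in opposite directions, so the outcome of this change depends on where the methyl sits. Compound 2 is reported only as a limit, < 1 nM, so the step to compound 3 is a floor and its full size cannot be read: the limit of < 1 nM in this assay, at which 1 of the 3 values shown sits.

The compounds shown hold this position only with hydrogen or methyl, so it remains open how a chlorine, a methoxy group or a longer chain such as ethyl would read there. Also open, from the compounds shown here alone, is whether the step at this place depends on the methyl already present in compound 2.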